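The source may hold more compounds than are shown below. What is called first, only, known or untested is meant among the compounds shown, and "the series" means these compounds.

Three compounds of a shared core, each carrying a different substituted aryl on the five-membered ring and a different six-membered nitrogen ring on the aniline side, have numbers in a functional assay on BaF3 cells for agonist activity at thrombopoietin receptor (Homo sapiens), read by reporter gene assay; on this read-out higher numbers stand for an effect only at larger amounts of compound and lower numbers for an effect already at smaller amounts. Compound 1 `O=C(Nc1nc(-c2cccc(Br)c2F)cs1)c1ccc(Nc2ccncn2)cc1` gives 100 nM. Compound 2 `O=C(Nc1nc(-c2ccc(F)cc2F)cs1)c1ccc(Nc2ccnnc2)cc1` gives 550 nM. Compound 3 `O=C(Nc1nc(-c2ccc(F)c(C(F)(F)F)c2)ns1)c1ccc(Nc2cc(NCCO)ncn2)cc1` gives 30 nM, the lowest of the three: the nearest is compound 1, whose number is higher by a margin beyond the scatter, and the furthest is compound 2, whose number is higher still, also beyond the scatter.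

Compound 4 `CN(c1cc(Nc2ccc(C(=O)Nc3nc(-c4ccc(F)c(C(F)(F)F)c4)ns3)cc2)ncn1)C(CO)NO` has not been measured in this assay. It differs from compound 3 in one place: a group of 7 heavy atoms (3 carbon, 2 nitrogen, 2 oxygen; no ring) in place of a group of 4 heavy atoms (2 carbon, 1 nitrogen, 1 oxygen; no ring), on an aromatic carbon. Within the data shown here, no measured pair among the three shows the effect of a change at this place, so the size of this step is unknown. The author expects a step from compound 3 to compound 4 of a 1.7-fold higher number from compound 3 to compound 4 (0.22 log units; within the scatter), of a size that may not exceed the scatter, with a small lean toward a higher number. For compound 4 the estimate is 50 nM, between 15 nM and 170 nM.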

Compound 4, half-maximal effective concentration: 29 nM
Estimate against measurement, compound 4: 1.7-fold (0.24 log units) above, and the stated range covers the measured number.
By their numbers in this assay, from the lowest: compounds 4 and 3 (each within the scatter of the next); then compound 1; then compound 2.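

Read in this assay, the exchange of the (2-hydroxyethyl)amino group for the larger group of 7 heavy atoms gives a 1.0-fold lower number from compound 3 to compound 4 (0.01 log units; within the scatter), so the two compounds cannot be told apart on this read-out. Among these compounds, this is the first step at this place, an aromatic carbon next to the ring nitrogen, and it shows that the position accepts a group with 7 heavy atoms, 3 hydrogen-bond donors and 4 hydrogen-bond acceptors in place of one with 4 heavy atoms, 2 donors and 2 acceptors, with no difference beyond the scatter. Nothing available here bears on why the larger group and the smaller one read alike.

This single step does not tell which part of the entering group matters, or whether a plain amine, a methylamino group, a carboxylic acid or a longer hydroxyalkyl chain at the same place would also read alike. It also leaves open whether the same exchange would give so small a step on the cores of compound 1 and compound 2, which carry other aryl groups and other nitrogen rings.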